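The source may report more compounds than this note shows. Statements on the series, on what has been measured and on what is new or still open speak of the compounds shown alone.

Among the measured compounds shown here, in a functional assay on HEp-2 cells (Homo sapiens) for cytotoxicity (a lower number here means a stronger inhibitor, a higher number a weaker inhibitor), three compounds have numbers so far. Compound 1 `CS(=O)(=O)c1nc(N)c2nnn(C3O[C@H](CO)[C@@H](O)[C@H]3O)c2n1` gives 14000 nM and compound 3 `CSc1nc(N)c2nn(C3O[C@H](CO)[C@@H](O)[C@H]3O)nc2n1` gives 25000 nM, two values that lie within the scatter of each other. Compound 2 `Nc1nc(N)c2nnn([C@@H]3O[C@H](CO)[C@@H](O)[C@H]3O)c2n1` gives 700 nM, well beyond the scatter from compound 3. Compound 3 therefore sits alongside compound 1 and far above compound 2 on this scale.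

Compound 4 `Nc1nc(N)c2nn(C3O[C@H](CO)[C@@H](O)[C@H]3O)nc2n1` has not yet been measured. It differs from compound 3 in one place, with amino in place of methylsulfanyl on an aromatic carbon, between two ring nitrogen atoms: amino in place of methylsulfanyl on an aromatic carbon. For the measured compounds named here, no measured pair isolates this change. The closest guide is compound 2, at 700 nM, which also carries amino there, but its core is not that of compound 4. A fall in the number beyond the scatter is expected, though smaller than the whole gap to compound 2. The estimated move is a 5.0-fold lower number from compound 3 to compound 4 (0.70 log units; beyond the scatter). For compound 4 the expected value is 5000 nM, with an estimated range of 800 nM to 20000 nM.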

Compound 4, half-maximal inhibitory concentration: > 75000 nM
Compound 4: only a limit was reported (the forecaster's own chance of this, stated with the estimate: 10%); at least 15-fold (1.17 log units) between middle value and limit.
By their numbers in this assay, from the lowest: compound 2; then compounds 1 and 3 (each within the scatter of the next). At a limit, above all of these: compound 4.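

Among the compounds shown here, on the shared core, amino in place of methylsulfanyl on the aromatic carbon between two ring nitrogen atoms gives an at least 3.0-fold higher number from compound 3 to compound 4 (0.47 log units; beyond the scatter) in this assay, the first measured pair to isolate this change. The direction is upward, so on this core amino at this position does not by itself bring the number down, and methylsulfanyl is the group of the pair with the lower number. For compound 4 the reading is a limit and not a number: the limit of > 75000 nM in this assay, at which 1 of the 4 values shown sits.

The full size of the step stays unknown, and the compounds shown do not tell whether the same change would run the same way on the core of compound 2. Nor do they show how a hydroxyl, a methoxy or a longer alkylsulfanyl chain at this position would stand against methylsulfanyl in this assay.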